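A few compounds are considered here, and "the series" means these few. Any claim that something is new, unique, unknown or untested is made for them only; others in the source may bear on it.

Measured compounds in a physicochemical assay for solubility, at pH 7.4; a higher number here means a more soluble compound, a lower number a less soluble compound:
- compound 1 `COCCNCCCS(=O)(=O)c1ccc2nc(NC(=O)NC(=O)c3ccccc3Cl)sc2c1`: 87000 nM
- compound 2 `CS(=O)(=O)c1ccc2nc(NC(=O)NC(=O)c3ccccc3Cl)sc2c1`: only a limit, < 470 nM
- compound 3 `CCN(CC)CCCS(=O)(=O)c1ccc2nc(NC(=O)NC(=O)c3ccccc3Cl)sc2c1`: 280000 nM

Compound 3 gives the highest of the two numbers in this set; compound 1 is nearest, and a 3.2-fold higher number from compound 1 to compound 3 (0.51 log units; beyond the scatter). Compound 2 sits at a limit of the assay, (the limit of < 470 nM in this assay, at which 1 of the 3 values shown sits).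

Compound 4 `CC(C)NCCS(=O)(=O)c1ccc2nc(NC(=O)NC(=O)c3ccccc3Cl)sc2c1` is not yet measured. The change from compound 3 is isopropylamino in place of (diethylamino)methyl on a saturated chain carbon, two bonds along the chain from a sulfonyl sulfur. Two kinds of measured step bear on it. The exchange of the amine alone, a 3.2-fold higher number from compound 1 to compound 3 (0.51 log units; beyond the scatter), was modest. Removal of the whole amine-bearing chain was large in both directions: an at least 180-fold lower number from compound 1 to compound 2 (2.26 log units; beyond the scatter) and an at least 590-fold higher number from compound 2 to compound 3 (2.77 log units; beyond the scatter). Compound 4 keeps an amine-bearing chain on the sulfonyl, (2-(isopropylamino)ethyl)sulfonyl rather than (3-(diethylamino)propyl)sulfonyl, so the step is expected to be of the modest kind, downward towards the number of compound 1, and not of the large kind seen with compound 2. For compound 4 the expected step is a 2.3-fold lower number from compound 3 to compound 4 (0.37 log units; beyond the scatter). Compound 4 is estimated at 120000 nM in this assay, with a range from 40000 nM to 350000 nM.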

Compound 4, solubility: 71000 nM
For compound 4 the middle estimate is 1.7-fold (0.23 log units) above the measured one; the measured number falls inside the stated range.
By their numbers in this assay, from the lowest: compounds 4 and 1 (each within the scatter of the next); then compound 3. At a limit, below all of these: compound 2.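

In this assay the amine-bearing chain on the sulfonyl keeps its large effect when shortened to 2-(isopropylamino)ethyl, with an at least 150-fold higher number from compound 2 to compound 4 (2.17 log units; beyond the scatter) as the step, so this effect does not depend on the 3-(diethylamino)propyl chain. Compound 2 gives only a limit: the limit of < 470 nM in this assay, at which 1 of the 4 values shown sits. The change from (3-(diethylamino)propyl)sulfonyl to (2-(isopropylamino)ethyl)sulfonyl is a modest one, with a 3.9-fold lower number from compound 3 to compound 4 (0.60 log units; beyond the scatter) as its size, and a 1.2-fold lower number from compound 1 to compound 4 (0.09 log units; within the scatter) leaves compound 1 and compound 4 indistinguishable despite their different amines and chains.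

Chain length and amine substitution change together from compound 3 to compound 4, so neither can be read alone. Also open, as far as these compounds go, is how a cyclic amine such as morpholine, a carboxylic acid or a longer chain would behave at this position.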